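The source may hold more compounds than are shown below. What is called first, only, known or untested is meant among the compounds shown, and "the series" means these compounds.

Measured so far in a functional assay on NCI-H460 cells (Homo sapiens) for antiproliferative activity, read by MTT assay, with a stated time of 72 h; on this read-out lower numbers stand for stronger inhibition and higher numbers for weaker inhibition:
compound 1 `CN(C)CCn1cnnc1-c1cc(Oc2ccc(NC(=O)Nc3ccc(Cl)cc3Cl)cc2F)ccn1` — 4350 nM
compound 2 `CCN(CC)CCn1cnnc1-c1cc(Oc2ccc(NC(=O)Nc3ccc(Cl)cc3Cl)cc2F)ccn1` — 5380 nM
compound 3 `CN(C)CCCn1cnnc1-c1cc(Oc2ccc(NC(=O)Nc3ccccc3C(F)(F)F)cc2F)ccn1` — 10900 nM

Compound 3 gives the highest number of the three in this assay, with its gaps to compound 2 and to compound 1 both beyond the usual scatter. Compound 4 `CN(C)CCCn1cnnc1-c1cc(Oc2ccc(NC(=O)Nc3ccc(Cl)cc3Cl)cc2F)ccn1` is not yet measured. The change from compound 3 to compound 4 is 2,4-dichlorophenyl in place of 2-(trifluoromethyl)phenyl on an amide-type nitrogen; the dimethylaminopropyl chain of compound 3 is kept. Going by the values given here, no measured pair isolates the aryl swap on this chain. Among the compounds with values here, compound 1 carries the same 2,4-dichlorophenyl on a shorter dimethylaminoethyl chain, and the one measured step on the amine end, a 1.2-fold higher number from compound 1 to compound 2 (0.09 log units; within the scatter), shows that variation there stays within the scatter. Compound 1 and compound 3 differ in both aryl and chain, so their two values only suggest that the dichlorophenyl series sits at the lower numbers. Compound 4 is therefore expected to land near compound 1, an estimated step of a 2.3-fold lower number from compound 3 to compound 4 (0.36 log units; beyond the scatter) downward. The estimate for compound 4 in this assay is 4800 nM, within a range of 2400 nM to 9600 nM.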

Compound 4, half-maximal inhibitory concentration: 3680 nM
Beside the measured number, compound 4's estimate is 1.3-fold (0.12 log units) above it; the range from low to high includes it.
By their numbers in this assay, from the lowest: compounds 4, 1 and 2 (each within the scatter of the next); then compound 3.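

In this assay, going by these compounds alone, the first pair to isolate the aryl group on the amide-type nitrogen, with the dimethylaminopropyl chain kept, gives a 3.0-fold lower number from compound 3 to compound 4 (0.47 log units; beyond the scatter), and this is the only one-place step so far beyond the scatter. With 2,4-dichlorophenyl held, the amine-end steps stay within the scatter: a 1.2-fold lower number from compound 1 to compound 4 (0.07 log units; within the scatter) and a 1.5-fold lower number from compound 2 to compound 4 (0.16 log units; within the scatter). No evidence at hand explains the gap between these two aryl groups.

On these data alone, whether the aryl step carries over to the dimethylaminoethyl or diethylaminoethyl chain remains open, as 2-(trifluoromethyl)phenyl appears here only with the dimethylaminopropyl chain. Also open, as far as these compounds go, is how an unsubstituted phenyl on the amide-type nitrogen, or a morpholine at the chain end, would read in this assay.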